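A few compounds are considered here, and "the series" means these few. Any claim that something is new, unique, unknown or untested is made for them only; others in the source may bear on it.

Working notes on the series. All three measured compounds share one core and differ only in the five-membered aromatic ring on the saturated chain carbon bound to a saturated ring carbon. In a functional assay on HUVEC cells (Homo sapiens), read by scintillation counting and thymidine incorporation, with a stated time of 24 h (a lower number here means a stronger inhibitor, a higher number a weaker inhibitor), compound 1 `CCC(C)n1ncn(-c2ccc(N3CCN(c4ccc(OC[C@@H]5CO[C@@](Cn6ccnc6C)(c6ccc(Cl)cc6Cl)O5)cc4)CC3)cc2)c1=O` gives 173 nM, the highest of the three numbers. In this assay compound 2 `CCC(C)n1ncn(-c2ccc(N3CCN(c4ccc(OC[C@@H]5CO[C@@](Cn6ccnc6C(C)C)(c6ccc(Cl)cc6Cl)O5)cc4)CC3)cc2)c1=O` gives 84 nM, and compound 3 `CCC(C)n1ncn(-c2ccc(N3CCN(c4ccc(OC[C@@H]5CO[C@@](Cn6cnc(C)c6)(c6ccc(Cl)cc6Cl)O5)cc4)CC3)cc2)c1=O` gives 102 nM in this assay. Of the steps between them, a 2.1-fold lower number from compound 1 to compound 2 (0.31 log units; beyond the scatter) is the only one beyond the scatter; a 1.7-fold lower number from compound 1 to compound 3 (0.23 log units; within the scatter) and a 1.2-fold higher number from compound 2 to compound 3 (0.08 log units; within the scatter) are both within it.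

Compound 4 `CCC(C)n1ncn(-c2ccc(N3CCN(c4ccc(OC[C@@H]5CO[C@@](Cn6nnnc6C)(c6ccc(Cl)cc6Cl)O5)cc4)CC3)cc2)c1=O` differs from compound 1 in one place: 5-methyl-1H-tetrazol-1-yl in place of 2-methyl-1H-imidazol-1-yl on a saturated chain carbon bound to a saturated ring carbon. For the measured compounds named here, none of the measured steps exchanges the ring itself; they alter only the substituent on the imidazole ring, in its kind or its place, and in this assay these alterations moved the number little. Going by the values given here, the steps that bear on the present change are therefore indirect, and the nearest is a 1.7-fold lower number from compound 1 to compound 3 (0.23 log units; within the scatter), which stayed within the scatter. On that basis compound 4 is expected to give a number near that of compound 1, with the expected step of a 1.2-fold higher number from compound 1 to compound 4 (0.06 log units; within the scatter) not clearly beyond the scatter. The estimate for compound 4 in this assay is 200 nM, expected to fall between 80 nM and 500 nM.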

Compound 4, half-maximal inhibitory concentration: 101 nM
Beside the measured number, compound 4's estimate is 2.0-fold (0.30 log units) above it; measured number inside the range.
By their numbers in this assay, from the lowest: compounds 2, 4, 3 and 1 (each within the scatter of the next, the first and the last beyond it).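

For the compounds shown here, this is the first exchange of the ring itself rather than of a substituent on it, and in this assay the change from 2-methyl-1H-imidazol-1-yl to 5-methyl-1H-tetrazol-1-yl gives a 1.7-fold lower number from compound 1 to compound 4 (0.23 log units; within the scatter) even though the ring now holds 4 nitrogen atoms in place of 2 and the group counts 4 hydrogen-bond acceptors in place of 2. Going by these compounds alone, the tetrazole also cannot be told apart from the other two imidazoles, with a 1.0-fold lower number from compound 3 to compound 4 (0.00 log units; within the scatter) and a 1.2-fold higher number from compound 2 to compound 4 (0.08 log units; within the scatter) as the remaining steps, so on a saturated chain carbon bound to a saturated ring carbon these four five-membered aromatic rings give numbers that mostly lie within the scatter of one another, the one exception being compounds 1 and 2. Nothing at hand accounts for this result.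

As far as these compounds go, it remains open whether the same tolerance extends to a 5-isopropyl-1H-tetrazol-1-yl group, which would show if the step seen with isopropyl on the imidazole carries over to the tetrazole. From the compounds shown here alone, it is also open how the number responds when the aromatic ring at this place gives way to a carboxylic acid or an open-chain amine.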